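The source may hold more compounds than are shown below. What is called first, only, known or untested is meant among the compounds shown, and "the series" means these compounds.

Compound 2 (`O=C(Nc1ccc(F)cc1)c1cccc(/C=C2\CC(=O)N(c3ccccc3)C2=O)c1`) is the starting point. In an ADME assay on HCT-116 cells (Homo sapiens) for cytotoxicity, read by MTT assay, with a stated time of 72 h (a higher number here means a weaker inhibitor, a lower number a stronger inhibitor), compound 2 gives > 100000 nM, which is a limit of the assay rather than a measured number. Compound 1 (`Cc1cccc(NC(=O)c2cccc(/C=C3\CC(=O)N(c4ccccc4)C3=O)c2)c1`) carries 3-methylphenyl where compound 2 carries 4-fluorophenyl on the amide-type nitrogen. In this assay compound 1 gives > 100000 nM, again a limit. The step that the two limits leave unreadable from compound 1 to compound 2 cannot be read in size because of the limit of > 100000 nM in this assay, at which 2 of the 2 values shown sit. Compound 3 (`O=C(Nc1ccc(Cl)cc1)c1cccc(/C=C2\CC(=O)N(c3ccccc3)C2=O)c1`) differs from compound 2 by chloro in place of fluoro on an aromatic carbon. For the measured compounds named here, the only measured step is unreadable, and no measured step matches this exchange, so nothing in these numbers points to a shift beyond the scatter. Compound 3 is therefore expected to remain at the limit, with the step that the limit leaves unreadable from compound 2 to compound 3 estimated as essentially none. For compound 3 in this assay the estimate is 150000 nM, within a range from 70000 nM to 400000 nM.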

Compound 3, half-maximal inhibitory concentration: > 100000 nM
Compound 3 gave a limit, no number; the forecaster's own chance of this, stated with the estimate: 85%; the middle value is on the limit's open side.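

For the compounds shown here, compound 3 also sits at a limit in this assay, not at a measured number, so no step among compound 1, compound 2 and compound 3 can be read in size: the limit of > 100000 nM in this assay, at which 3 of the 3 values shown sit.

Going by these compounds, what values these three compounds have past that limit, and whether they differ from one another at all, stays open.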